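This account rests on a few compounds, and the source may have more. Where it says the series, first, only, none or still open, it means among the compounds named here.

Compound 1 `N#C/N=C(\N)NCCCCc1c[nH]cn1`, compound 2 `CN/C(=N\C#N)NCCCCc1c[nH]cn1`, compound 3 `CCN/C(=N\C#N)NCCCCc1c[nH]cn1` and compound 4 `CC(C)N/C(=N\C#N)NCCCCc1c[nH]cn1` share one core and differ only in what sits on the amine nitrogen. In an in vitro functional assay on Sf9 cells for antagonist activity at histamine H2 receptor (Homo sapiens) (a higher number here means a more potent compound, by a factor of ten per unit of this negative logarithm, a lower number a less potent compound), compound 1 gives only a limit, < 5. Compound 2 likewise reaches only a limit, < 5. Compound 3 also stops at a limit, < 5, so it stands at the edge of what this assay resolves. All three measured values sit at the same limit (the limit of < 5 in this assay, at which 3 of the 3 values shown sit). The change to compound 4 is methyl in place of hydrogen on a saturated chain carbon bound to an amine nitrogen and a saturated chain carbon. The steps a step that the two limits leave unreadable from compound 1 to compound 2, a step that the two limits leave unreadable from compound 1 to compound 3 and a step that the two limits leave unreadable from compound 2 to compound 3 stay unreadable, so no size can be taken from them. Compound 4 is therefore expected to remain at the limit, with a step that the limit leaves unreadable from compound 3 to compound 4 of no readable size. The estimate for compound 4 is 4.5, from 3.5 to 5.2.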

Compound 4, negative logarithm of the antagonist equilibrium constant: < 5
Compound 4 ended at the assay's limit; the forecaster's own chance of this, stated with the estimate: 85%; the middle value does not contradict the limit.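

Among the compounds shown here, compound 4 stops at a limit, as do compound 1, compound 2 and compound 3, so no step among them can be read: the limit of < 5 in this assay, at which 4 of the 4 values shown sit. In this assay the compounds shown leave open whether any group on the amine nitrogen changes potency.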